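Quinoxaline-fused bicyclic amines: hydroxy in place of 4-chlorophenyl

This account rests on a few compounds, and the source may have more. Where it says the series, first, only, none or still open, it means among the compounds named here.

Measured so far:
compound 1 `Clc1ccc(-c2cnc3cc4c(cc3n2)C2CNCC4C2)cc1` — 78 nM
compound 2 `c1cnc2cc3c(cc2c1)C1CNCC3C1` — 1.6 nM

In an assay for binding affinity to Neuronal acetylcholine receptor; alpha4/beta2 (Rattus norvegicus) (on this read-out higher numbers stand for weaker inhibition and lower numbers for stronger inhibition), compound 1 gives 78 nM, the highest of the two numbers; compound 2 on a different core gives 1.6 nM, and the two values show a gap beyond the usual scatter. Going by the values given here, no step between measured compounds that differ in one place is available. Compound 3 `Oc1cnc2cc3c(cc2n1)C1CNCC3C1` is not yet measured; it differs from compound 1 by hydroxy in place of 4-chlorophenyl on an aromatic carbon. Among the compounds with values here, since no step is known for this change, the expectation rests on the two values: compound 3 is expected to move toward a stronger number, a 3.9-fold lower number from compound 1 to compound 3 (0.59 log units; beyond the scatter), estimated at 20 nM within 4 nM to 100 nM.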

Compound 3, inhibition constant: < 6 nM
Compound 3 gave a limit, no number; the forecaster's own chance of this, stated with the estimate: 5%; middle value at least 3.3-fold (0.52 log units) from the limit.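

In this assay compound 3 gives < 6 nM, which is a limit of the assay and not a number. Hydroxy in place of 4-chlorophenyl on this aromatic carbon gives an at least 13-fold lower number from compound 1 to compound 3 (1.11 log units; beyond the scatter), the first single-place step in the series and a large one. On this core, the low number therefore does not depend on keeping the 4-chlorophenyl at this position.

Going by these compounds, the full size of the step stays unknown while compound 3 has only a limit. On these data alone, whether an amine or a methoxy group at this position would give a similar number remains open.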